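This account rests on a few compounds, and the source may have more. Where it says the series, first, only, none or still open, it means among the compounds named here.

Compound 1 `CCC1C(=O)N(C)c2cnc(-n3ccc4cc(C(=O)NC(C)C)ccc43)nc2N1c1ccn(C)n1` carries an isopropyl group on an amide-type nitrogen. In an assay for inhibition of serine/threonine-protein kinase PLK2 (Homo sapiens), read by FRET and Z'-LYTE, with a stated time of 1 h (a lower number here means a stronger inhibitor, a higher number a weaker inhibitor), compound 1 gives 125 nM. Compound 2 `CCCNC(=O)c1ccc2c(ccn2-c2ncc3c(n2)N(c2ccn(C)n2)C(CC)C(=O)N3C)c1` differs from it in one place: propyl in place of isopropyl on an amide-type nitrogen. In this assay compound 2 gives 207 nM, so the swap made a step of a 1.7-fold higher number from compound 1 to compound 2 (0.22 log units; within the scatter).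

Compound 3 `CC[C@@H]1C(=O)N(C)c2cnc(-n3ccc4cc(C(=O)NC(C)C)ccc43)nc2N1C1CCCC1` is built on a different core; the difference between the core of compound 1 and the core of compound 3 is not broken down here. In this assay compound 3 gives 17.4 nM, the strongest inhibitor of the three, with the steps to compound 1 and compound 2 both beyond the scatter.

Compound 4 `CCCNC(=O)c1ccc2c(ccn2-c2ncc3c(n2)N(C2CCCC2)[C@H](CC)C(=O)N3C)c1` has not been measured. It relates to compound 3 exactly as compound 2 relates to compound 1: propyl in place of isopropyl on an amide-type nitrogen. Since the place of the change is the same in both pairs, this is the same change. Compound 4 is expected to show a step of a 1.6-fold higher number from compound 3 to compound 4 (0.21 log units; within the scatter), beside the measured 1.7-fold higher number from compound 1 to compound 2 (0.22 log units; within the scatter). The estimate for compound 4 in this assay is therefore 28 nM, expected between 12 nM and 65 nM.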

Compound 4, half-maximal inhibitory concentration: 11.4 nM
Compound 4: middle estimate off by 2.5-fold (0.39 log units), on the high side, outside the stated range (below it).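

On the core of compound 3, putting propyl in place of isopropyl on the amide-type nitrogen gives a 1.5-fold lower number from compound 3 to compound 4 (0.18 log units; within the scatter) in this assay. Set beside the same swap on the core of compound 1, neither the steps nor the gap between them stands out from the scatter: the same change on two cores in this assay, a 1.7-fold higher number (0.22 log units; within the scatter) from compound 1 to compound 2 and a 1.5-fold lower number (0.18 log units; within the scatter) from compound 3 to compound 4, 2.5-fold (0.40 log units) apart, within the scatter of two such steps. The two chains therefore cannot be told apart on either core, and on these two pairs the swap carries from one core to the other without a measurable difference, but two pairs cannot show that this holds on other cores, and they give no reason to read the two steps as truly different.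

The compounds shown hold only isopropyl and propyl at this place, so they cannot say how far this tolerance extends. A longer chain such as butyl, a cyclopropyl group or a chain ending in an amine or a carboxylic acid remains an open question on either core.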